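This account rests on a few compounds, and the source may have more. Where it says the series, first, only, none or still open, it means among the compounds named here.

Measured so far:
Compound 1, `COc1ccc(S(=O)(=O)Nc2ccc(-c3nc4ccccc4o3)cc2)cc1`: in an ADME assay on HEK293 cells (Homo sapiens) for cytotoxicity, read by resazurin assay, with a stated time of 48 h (a higher number here means that more compound is tolerated, a lower number that less compound is tolerated), compound 1 gives > 100000 nM, which is a limit of the assay and not a number.
Compound 2, `C=Cc1ccc(S(=O)(=O)Nc2ccc(-c3nc4ccccc4o3)cc2)cc1`: in this assay compound 2 gives > 100000 nM, again a limit of the assay rather than a number.

Compound 2 therefore stands only at a limit in this assay, with no measured number of its own. Among the measured compounds shown here, the one measured step, a step that the two limits leave unreadable from compound 1 to compound 2, is unreadable because both of its compounds sit at the limit of > 100000 nM in this assay, at which 2 of the 2 values shown sit.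

Compound 3, `COc1cccc(S(=O)(=O)Nc2ccc(-c3nc4ccccc4o3)cc2)c1`, is the next to be measured in this assay. The change is 3-methoxyphenyl in place of 4-vinylphenyl on a sulfonyl sulfur. For the measured compounds named here, no measured step addresses this change directly; the only step available, a step that the two limits leave unreadable from compound 1 to compound 2, gives no size, and nothing here separates one aryl sulfonamide from another in this assay.

Given that both measured compounds rest at the limit of > 100000 nM in this assay, at which 2 of the 2 values shown sit, compound 3 is expected to show at most a step that the limit leaves unreadable from compound 2 to compound 3 beyond the scatter in this assay, most likely none. The estimate for compound 3 in this assay is 150000 nM, with a range from 50000 nM to 500000 nM, and a limit rather than a number is the expected outcome.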

Compound 3, half-maximal cytotoxic concentration: > 100000 nM
Compound 3 ended at the assay's limit; the forecaster's own chance of this, stated with the estimate: 80%; the middle value does not contradict the limit.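

No new step can be read among compound 1, compound 2 and compound 3 in this assay, because all three rest at a limit of the assay and not at a number: the limit of > 100000 nM in this assay, at which 3 of the 3 values shown sit.

The compounds shown leave open whether 4-methoxyphenyl, 4-vinylphenyl and 3-methoxyphenyl on the sulfonyl sulfur differ at all in this assay.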